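Swapping methyl for cyano on two pyrazole-based FAAH inhibitors

The compounds below may be only part of what the source reports. "The series", "measured", "known", "first", "only" and "open" are said of these compounds alone.

Four compounds built on a five-membered aromatic ring with two nitrogens are compared in an assay on isolated protein for inhibition of Fatty-acid amide hydrolase 1 (Rattus norvegicus), with a stated time of 3 h; a higher number here means a weaker inhibitor, a lower number a stronger inhibitor. Compound 1 `Cc1cnn(C(=O)NCCCCc2ccccc2)c1` carries a methyl on the ring and an amide linker; in this assay compound 1 gives 550 nM. Compound 2 `N#Cc1cnn(C(=O)NCCCCc2ccccc2)c1` differs from it by one change, (cyano in place of methyl on an aromatic carbon), and compound 2 gives 42 nM. That single change produced a 13-fold lower number from compound 1 to compound 2 (1.12 log units; beyond the scatter).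

Compound 3 `Cc1cnn(C(=O)CCCCCc2ccccc2)c1` keeps the methyl but replaces the amide linker with a ketone chain; the difference between the two cores is not broken down here. In this assay compound 3 reaches only > 5000 nM, which is a limit of the assay and not a number. This is the limit of > 5000 nM in this assay, at which 1 of the 3 values shown sits.

Compound 4 `N#Cc1cnn(C(=O)CCCCCc2ccccc2)c1` is not yet measured. It differs from compound 3 by cyano in place of methyl on an aromatic carbon, the same change as that from compound 1 to compound 2, made at the same place on the ring. Resting on a 13-fold lower number from compound 1 to compound 2 (1.12 log units; beyond the scatter), the expectation for compound 4 is a similar gain, an at least 2.0-fold lower number from compound 3 to compound 4 (0.30 log units; that floor lies within the scatter), though the starting point is only a limit. Compound 4 is therefore expected at about 2500 nM, most likely between 600 nM and 10000 nM.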

Compound 4, inhibition constant: > 5000 nM
Compound 4 gave a limit, no number; the forecaster's own chance of this, stated with the estimate: 40%; middle value at least 2.0-fold (0.30 log units) from the limit.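

In this assay, compound 3 and compound 4 each give only a limit of the assay and not a number, so no step between them can be read: the limit of > 5000 nM in this assay, at which 2 of the 4 values shown sit.

The compounds shown leave open whether cyano in place of methyl changes inhibition at all when the ketone chain replaces the amide linker.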